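The source may report more compounds than this note shows. Statements on the series, on what has been measured and on what is new or still open speak of the compounds shown alone.

The measured compounds:
compound 1 `O=C1NC(=O)/C(=C/C(c2ccc(-c3ccc4cccc(F)c4c3)[nH]c2=O)C2CC2)O1`, 22 nM
compound 2 `CC(C)[C@@H](c1ccc(-c2ccc3cccc(F)c3c2)[nH]c1=O)[C@H]1OC(=O)NC1=O`, 27 nM
compound 3 `CC(C)C(c1ccc(-c2ccc3cccc(F)c3c2)[nH]c1=O)C1C(=O)NC(=O)N1C`, 46 nM

All three numbers come from an assay on membranes from Chem-1 cells for displacement of a labelled ligand from prostaglandin E2 receptor EP3 subtype (Homo sapiens), read by scintillation counting, with a stated time of 2 h; a lower number here means a stronger inhibitor, a higher number a weaker inhibitor. Compound 3 has the highest of the three numbers. Its gap to compound 2 lies within the usual scatter of the measurement, so nothing can be said about which of the two is the stronger binder. Its gap to compound 1 lies beyond the scatter, so compound 1 is the stronger binder of that pair.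

The next compound, compound 4 `CC(C)C(/C=C1/C(=O)NC(=O)N1C)c1ccc(-c2ccc3cccc(F)c3c2)[nH]c1=O`, is not yet measured in this assay. It differs from compound 3 in one place: a group of 9 heavy atoms (5 carbon, 2 nitrogen, 2 oxygen; one five-membered non-aromatic ring with 2 hetero atoms) in place of a group of 8 heavy atoms (4 carbon, 2 nitrogen, 2 oxygen; one five-membered non-aromatic ring with 2 hetero atoms), on a saturated chain carbon bound to an aromatic carbon and a saturated chain carbon. Within the data shown here, no step between two measured compounds matches this change. The nearest hint is what compound 2 gives, 27 nM, against what compound 1 gives, 22 nM, where the two values sit within the scatter of each other, though those two compounds also differ elsewhere.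

On that basis the step from compound 3 to compound 4 is expected to be small, perhaps toward a slightly lower number, and within the scatter: a 1.3-fold lower number from compound 3 to compound 4 (0.12 log units; within the scatter). Compound 4 is therefore estimated at 35 nM in this assay, with a likely range from 12 nM to 100 nM.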

Compound 4, inhibition constant: 6 nM
The estimate for compound 4 lay 5.8-fold (0.77 log units) above the measured number; measured number below the stated range.
By their numbers in this assay, from the lowest: compound 4; then compounds 1, 2 and 3 (each within the scatter of the next, the first and the last beyond it).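

In this assay, among these compounds, the exchange on the saturated chain carbon bound to an aromatic carbon and a saturated chain carbon gives a 7.7-fold lower number from compound 3 to compound 4 (0.88 log units; beyond the scatter), the first change in a single place that can be read in this set, and it shows that binding at this position responds clearly to a modest change of group. The 3-methyl-2,5-dioxoimidazolidin-4-yl group and the group of 9 heavy atoms that replaces it have the same ring count, hydrogen-bond donor and acceptor counts and net charge, so the gain comes with no change in those counts, while the double bonds outside aromatic rings go from 2 to 3 and the heavy atoms from 8 to 9. Nothing measured here explains why the number falls.

These compounds do not separate the added double bond from the added carbon, and a saturated group with a methylene link to the same ring would be needed to tell the two apart. On these data alone, it also remains open how far this position tolerates other groups, such as a carboxylic acid or an amine, or a longer chain in place of the methyl on the ring.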